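A few compounds are considered here, and "the series" means these few. Any claim that something is new, unique, unknown or untested is made for them only; others in the source may bear on it.

Measured so far:
- compound 1, `c1nnc2nnc(N3CCCC3)nn12`: 24400 nM
- compound 2, `OCC(CO)(CO)Nc1nnc2nncn2n1`: > 100000 nM
- compound 3, `CCCCNc1nnc2nncn2n1`: 36200 nM

All three were tested in a functional assay on HL-60 cells (Homo sapiens) for inhibition, read by MTT assay, with a stated time of 72 h; a higher number here means a weaker inhibitor, a lower number a stronger inhibitor. Compound 1 gives 24400 nM and compound 3 gives 36200 nM, and these two numbers are close enough that the usual scatter of repeated measurements does not separate them. For compound 2 the assay reports only a limit, > 100000 nM, and not a number (the limit of > 100000 nM in this assay, at which 1 of the 3 values shown sits). So compound 3 stands as one of just two actual numbers, with compound 1 as its nearest neighbour.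

The next compound, compound 4, `c1nnc2nnc(NC3CCCC3)nn12`, shares the core of compound 3 and differs from it in one place: cyclopentyl in place of butyl on a nitrogen on an aromatic ring. For the measured compounds named here, no measured pair here shows what such a swap does in this assay, so the expectation rests on the size of the change alone. Both groups are small hydrocarbon pieces of similar size on the same nitrogen, and a change of this kind is expected to move the number little, if at all, beyond the scatter. The step I expect, a 1.2-fold lower number from compound 3 to compound 4 (0.08 log units; within the scatter), is therefore small in either direction. Compound 4 is estimated to give about 30000 nM in this assay, most likely between 10000 nM and 90000 nM.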

Compound 4, half-maximal inhibitory concentration: 38200 nM
Compound 4: middle estimate off by 1.3-fold (0.10 log units), on the low side; the range from low to high includes it.
By their numbers in this assay, from the lowest: compounds 1, 3 and 4 (each within the scatter of the next). At a limit, above all of these: compound 2.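

In this assay, for the compounds shown here, the swap of cyclopentyl for butyl on a nitrogen on an aromatic ring gives a 1.1-fold higher number from compound 3 to compound 4 (0.02 log units; within the scatter) and provides the first measured pair in this set that tests a change at this position. For these two groups, then, the assay does not separate an open chain from a five-membered ring of carbon, so this position tolerates that particular change in shape without a change that the measurement can resolve. Nothing measured here explains this result or assigns a property to either group.

As far as these compounds go, what a group of a different kind would do on this same nitrogen remains open, whether a carboxylic acid, a phenyl ring, or a chain longer than butyl, and any of these might or might not move the number beyond the scatter. From the compounds shown here alone, it is also open whether a larger ring such as cyclohexyl or a branched group such as tert-butyl would read like cyclopentyl, or whether the tolerance seen here ends somewhere short of them.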